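Working notes: from compound 3 to compound 4

A few compounds are considered here, and "the series" means these few. Any claim that something is new, unique, unknown or untested is made for them only; others in the source may bear on it.

Of the compounds shown here, three have been measured in a functional assay on MES-SA cells (Homo sapiens) for cytotoxicity, read by luminescence and CellTiter-Glo, with a stated time of 72 h; a higher number here means a weaker inhibitor, a lower number a stronger inhibitor. Compound 1 (`COC[C@H](NC(=O)c1cc(C)on1)C(=O)N[C@@H](CC(C)C)C(=O)N[C@@H](CC(C)C)C(=O)[C@@]1(C)CO1`) gives 366 nM. Compound 3 (`COC[C@H](NC(=O)c1cc(C)on1)C(=O)N[C@@H](CC#N)C(=O)N[C@@H](CC(C)C)C(=O)[C@@]1(C)CO1`) gives 941 nM, the higher of the two actual numbers. Compound 2 (`Cc1cc(C(=O)N[C@@H](CC(C)C)C(=O)N[C@@H](CCc2ccccc2)C(=O)N[C@@H](CC(C)C)C(=O)[C@@]2(C)CO2)n[nH]1`) gives > 1000 nM, which is a limit of the assay and not a number.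

Compound 4 (`COC[C@H](NC(=O)c1cc(C)on1)C(=O)N[C@@H](C)C(=O)N[C@@H](CC(C)C)C(=O)[C@@]1(C)CO1`) has not yet been measured. It differs from compound 3 by hydrogen in place of cyano on a saturated chain carbon, two bonds along the chain from an amide-type nitrogen and a carbonyl carbon, which also reads as cyanomethyl to methyl: hydrogen in place of cyano on a saturated chain carbon, two bonds along the chain from an amide-type nitrogen and a carbonyl carbon.

Within the data shown here, one measured step bears on this place, where isopropyl gives way to cyano: a 2.6-fold higher number from compound 1 to compound 3 (0.41 log units; beyond the scatter). Among the measured compounds shown here, compound 2 differs in more than one place and offers no step. For the measured compounds named here, that single modest step shows that changes here can move the number, but it does not fix a direction for this new change, and no measured compound yet carries the methyl. No shift beyond the scatter is therefore expected in this assay, with only a slight lean towards a lower number. The expected step is a 1.2-fold lower number from compound 3 to compound 4 (0.07 log units; within the scatter). For compound 4 the estimated value is 800 nM, with an expected range of 300 nM to 2000 nM.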

Compound 4, half-maximal inhibitory concentration: 276 nM
For compound 4 the middle estimate is 2.9-fold (0.46 log units) above the measured one; measured number outside the range, below it.
By their numbers in this assay, from the lowest: compounds 4 and 1 (each within the scatter of the next); then compound 3. At a limit, above all of these: compound 2.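

In this assay, the step of a 3.4-fold lower number from compound 3 to compound 4 (0.53 log units; beyond the scatter) gives this position its first change that lowers the number, and it shows that the earlier rise on going to the nitrile can be undone at the same carbon. The second step, a 1.3-fold lower number from compound 1 to compound 4 (0.12 log units; within the scatter), lies within the scatter, so the methyl of compound 4 and the isopropyl-ended chain of compound 1 cannot be told apart here, even though hydrogen replaces the whole isopropyl group. Among the three compounds that differ only at this place, compound 3 alone stands apart, which places the nitrile rather than the shortening of the chain with the higher number, and no compound shown goes against this reading.

Going by these compounds, whether this holds only for the nitrile remains open, as does the question of how other end groups on this chain would behave: a primary amine, a carboxylic acid or a longer plain carbon chain at this carbon would test it. Nothing given here bears on why the number moves at this position.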